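This account rests on a few compounds, and the source may have more. Where it says the series, first, only, none or still open, it means among the compounds named here.

Working notes on the series. Among the compounds with values here, in a functional assay on SK-BR-3 cells (Homo sapiens) for antiproliferative activity (on this read-out higher numbers stand for weaker inhibition and lower numbers for stronger inhibition), compound 1 `CC(C)=CCc1cc(C(=O)Nc2cc3ccc(OCCC4CCCCN4)c(C)c3oc2=O)ccc1O` gives 640 nM, the second highest of the three numbers measured so far; its nearest neighbour is compound 2 `CC(C)=CCc1cc(C(=O)Nc2cc3ccc(OCC4CCCNC4)c(C)c3oc2=O)ccc1O`, which gives 600 nM, and furthest is compound 3 `CCNCCCOc1ccc2cc(NC(=O)c3ccc(O)c(CC=C(C)C)c3)c(=O)oc2c1C`, which gives 720 nM. The steps of a 1.1-fold lower number from compound 1 to compound 2 (0.03 log units; within the scatter), a 1.1-fold higher number from compound 1 to compound 3 (0.05 log units; within the scatter) and a 1.2-fold higher number from compound 2 to compound 3 (0.08 log units; within the scatter) all sit within the scatter, so the three compounds cannot be ordered. Compound 4 `COC(=O)CNCCCOc1ccc2cc(NC(=O)c3ccc(O)c(CC=C(C)C)c3)c(=O)oc2c1C` differs from compound 1 by (((methoxycarbonyl)methyl)amino)methyl in place of piperidin-2-yl on a saturated chain carbon, two bonds along the chain from an oxygen on an aromatic ring. The step of a 1.1-fold higher number from compound 1 to compound 3 (0.05 log units; within the scatter) bears most directly on this change, with the same piperidin-2-yl replaced at the same place by an open chain, and a 1.2-fold higher number from compound 2 to compound 3 (0.08 log units; within the scatter) points the same way. No step beyond the scatter is therefore expected in this assay. Compound 4 is expected to give 700 nM, with a range of 350 nM to 1400 nM. The expected step is a 1.1-fold higher number from compound 1 to compound 4 (0.04 log units; within the scatter), within the scatter.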

Compound 4, half-maximal inhibitory concentration: 1060 nM
Compound 4: the middle estimate sits 1.5-fold (0.18 log units) below what was measured, within the range that was stated.
By their numbers in this assay, from the lowest: compounds 2, 1, 3 and 4 (each within the scatter of the next).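

The methoxycarbonyl-bearing open chain extends the changes seen at this position, on a saturated chain carbon, two bonds along the chain from an oxygen on an aromatic ring, and still gives no step beyond the scatter: a 1.7-fold higher number from compound 1 to compound 4 (0.22 log units; within the scatter) and a 1.8-fold higher number from compound 2 to compound 4 (0.25 log units; within the scatter). Methoxycarbonyl in place of methyl on a saturated chain carbon bound to an amine nitrogen likewise stays within the scatter: a 1.5-fold higher number from compound 3 to compound 4 (0.17 log units; within the scatter). No measurement bears on why these numbers fall as they do. Going by these compounds, whether a carboxylic acid in place of methoxycarbonyl, or a longer chain carrying the amine, would give a step beyond the scatter remains open.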